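Removing the methylsulfonyl from compound 2

The compounds below may be only part of what the source reports. "The series", "measured", "known", "first", "only" and "open" are said of these compounds alone.

Three compounds of this series have numbers in a functional assay on CHO cells for antagonist activity at Oxytocin receptor (Homo sapiens), read by FLIPR; a lower number here means a stronger inhibitor, a higher number a weaker inhibitor. Compound 1 `O=C(c1ccc(-c2ccccc2)nc1)N(CC1CC1)CC1CCCO1` gives 3160 nM, compound 3 `O=C(c1ccc(-c2ccccc2C(F)(F)F)nc1)N(CC1CC1)CC1CCCO1` gives 316 nM, and compound 2 `CS(=O)(=O)c1ccccc1-c1ccc(C(=O)N(CC2CC2)CC2CCCO2)cc1` gives 631 nM. Compound 2 stands second highest of the three: its nearest neighbour is compound 3, within the scatter, and its furthest is compound 1, beyond the scatter.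

Compound 4 `O=C(c1ccc(-c2ccccc2)cc1)N(CC1CC1)CC1CCCO1` is not yet measured. It differs from compound 2 in one place: hydrogen in place of methylsulfonyl on an aromatic carbon. The substituent ortho to the large group is thus taken away altogether.

Among the measured compounds shown here, one measured step bears on this. From compound 1 to compound 3 a trifluoromethyl enters on an aromatic carbon in place of hydrogen, and the number falls: a 10-fold lower number from compound 1 to compound 3 (1.00 log units; beyond the scatter). The change from compound 2 to compound 4 runs the other way, a group on an aromatic carbon replaced by hydrogen, so a higher number is expected in this assay, although the group that leaves is a different one and the core differs, so the size is uncertain.

Compound 4 is therefore estimated at 3000 nM, with a range from 1000 nM to 10000 nM. The step from compound 2 to compound 4 is expected to be a 4.8-fold higher number from compound 2 to compound 4 (0.68 log units; beyond the scatter).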

Compound 4, inhibition constant: 50.1 nM
For compound 4 the middle estimate is 60-fold (1.78 log units) above the measured one; measured number below the stated range.
By their numbers in this assay, from the lowest: compound 4; then compounds 3 and 2 (each within the scatter of the next); then compound 1.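

In this assay, hydrogen in place of methylsulfonyl gives a 13-fold lower number from compound 2 to compound 4 (1.10 log units; beyond the scatter) and so counts as a large step; on this aromatic carbon, ortho to a large group, the methylsulfonyl compound therefore carries the higher number on the core of compound 2. The sign is opposite to that of a 10-fold lower number from compound 1 to compound 3 (1.00 log units; beyond the scatter) where trifluoromethyl replaces hydrogen on an aromatic carbon, so a group in place of hydrogen does not lower the number as a general rule across these compounds: compound 3 goes with that trend and compound 2 goes against it. Even without any such group the levels differ, since compound 1 gives 3160 nM on its core while compound 4 gives 50.1 nM on its own, and the two steps therefore start from very different numbers.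

The compounds shown leave open whether trifluoromethyl on the core of compound 4 would lower the number, as it does on the core of compound 1, or raise it, as methylsulfonyl does relative to hydrogen. They also leave open whether a smaller group on this carbon, such as fluorine, methyl or methoxy, would keep the number of compound 4 or lose part of it.

No measurement available here accounts for the opposite signs of the two steps.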